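Ester to nitrile at the sulfonyl-bearing chain carbon

A few compounds are considered here, and "the series" means these few. Any claim that something is new, unique, unknown or untested is made for them only; others in the source may bear on it.

Measured in a functional assay on MT4 cells (Homo sapiens) for antiproliferative activity, read by MTT assay, with a stated time of 96 h; on this read-out higher numbers stand for an effect only at larger amounts of compound and lower numbers for an effect already at smaller amounts:
- compound 1 `CCOC(=O)/C(=C/c1c[nH]c2ccccc12)C(=O)c1ccc([N+](=O)[O-])cc1`: 100000 nM
- compound 2 `COC(=O)/C(=C\c1c(-c2ccccc2)[nH]c2ccccc12)S(=O)(=O)c1ccccc1`: 1000 nM
- compound 3 `COC(=O)/C(=C\c1c[nH]c2ccccc12)S(=O)(=O)c1ccccc1`: the value is a limit of the assay, > 100000 nM the limit of > 100000 nM in this assay, at which 1 of the 3 values shown sits.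

Compound 2 gives 1000 nM, the lower of the two numbers, and compound 1 gives 100000 nM. The value of compound 3 is a limit and not a number. Among the compounds with values here, the only measured step, an at least 100-fold higher number from compound 2 to compound 3 (2.00 log units; beyond the scatter), is large and concerns the phenyl on the aromatic carbon; it leaves the chain substituent untouched and so does not bear on the change now considered.

Compound 4 `N#C/C(=C\c1c(-c2ccccc2)[nH]c2ccccc12)S(=O)(=O)c1ccccc1` differs from compound 2 by cyano in place of methoxycarbonyl on a double-bonded chain carbon bound to a double-bonded chain carbon and a sulfonyl sulfur. Within the data shown here, no measured pair in this set shows what such an exchange does in this assay, so no direction can be taken from the data; the expectation is a step that stays within the scatter. The expected step of a 1.5-fold higher number from compound 2 to compound 4 (0.18 log units; within the scatter) is therefore small. For compound 4 the number is estimated at 1500 nM, with a range from 400 nM to 6000 nM.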

Compound 4, half-maximal effective concentration: 400 nM
Beside the measured number, compound 4's estimate is 3.8-fold (0.57 log units) above it; the range from low to high includes it.
By their numbers in this assay, from the lowest: compound 4; then compound 2; then compound 1.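

In this assay, within the data shown here, cyano in place of methoxycarbonyl on the double-bonded chain carbon bound to a double-bonded chain carbon and a sulfonyl sulfur gives a 2.5-fold lower number from compound 2 to compound 4 (0.40 log units; beyond the scatter), the first measured reading on this position. Methoxycarbonyl is therefore not required at this carbon for the effect in this pair, although the step is modest compared with an at least 100-fold higher number from compound 2 to compound 3 (2.00 log units; beyond the scatter), the change on the aromatic carbon. Nothing at hand gives a cause for this step.

Only this one exchange is shown at this carbon, with phenyl on the aromatic carbon, so whether it carries over when hydrogen stands in place of phenyl remains open. Also open, from the compounds shown here alone, is how a carboxylic acid or a primary amide at this carbon would compare with cyano and methoxycarbonyl.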